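A few compounds are considered here, and "the series" means these few. Any claim that something is new, unique, unknown or untested is made for them only; others in the source may bear on it.

Measured in an ADME assay on MDCK cells (Canis lupus familiaris) for cytotoxicity; a higher number here means that more compound is tolerated, a lower number that less compound is tolerated:
- Compound 1 `O=[N+]([O-])C1=CNc2ncnn2C1c1c(O)cc(O)cc1O`: > 1030000 nM (a limit)
- Compound 2 `O=[N+]([O-])C1=CNc2ncnn2C1c1ccc(O)cc1O`: > 1080000 nM (a limit)

Compound 1 has no exact value in this assay: it stands at the limit > 1030000 nM. Compound 3 `O=[N+]([O-])C1=CNc2nc(-c3ccco3)nn2C1c1c(O)cc(O)cc1O` keeps the core of compound 1 and changes in one place: furan-2-yl in place of hydrogen on an aromatic carbon. The furan-2-yl enters in place of hydrogen on an aromatic carbon of the five-membered aromatic ring with 3 nitrogen.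

Among the measured compounds shown here, the only measured step is a step that the two limits leave unreadable from compound 1 to compound 2. It concerns a hydroxy group, not this place, and gives no size to carry over. The expectation is therefore weak: a modest fall in tolerated concentration, or a result again reported only as a limit. The expected step is an at least 1.4-fold lower number from compound 1 to compound 3 (0.16 log units; that floor lies within the scatter). For compound 3 the estimated value is 700000 nM, with an expected range of 250000 nM to 1200000 nM.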

Compound 3, half-maximal cytotoxic concentration: 280000 nM
Compound 3: the middle estimate sits 2.5-fold (0.40 log units) above what was measured; measured number inside the range.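

In this assay, furan-2-yl in place of hydrogen on the aromatic carbon between two ring nitrogen atoms gives an at least 3.6-fold lower number from compound 1 to compound 3 (0.56 log units; beyond the scatter). This position therefore responds to substitution in this read-out, something the hydroxy change could not show: the step from compound 1 to compound 2 cannot be read, as both values are limits. The furan-2-yl step has a floor and no exact size because compound 1 stands at a limit: the limit of > 1030000 nM in this assay, at which 1 of the 3 values shown sits.

From the compounds shown here alone, whether the fall belongs to furan-2-yl itself or to any group at this carbon stays open; a methyl, an amine or a phenyl at the same place would separate the two readings. Also open, going by these compounds, is whether furan-2-yl gives a similar step on the core of compound 2.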